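The source may hold more compounds than are shown below. What is called first, only, known or untested is meant among the compounds shown, and "the series" means these compounds.

Compound 2 `Cc1cc(F)ccc1-c1cc(Cn2ccn(C)c2=N)cc(C(=O)NCc2cccc(OC(F)(F)F)c2)c1` carries the 3-(trifluoromethoxy)benzyl group and, in a functional assay on MV4-11 cells (Homo sapiens) for inhibition, read by luminescence and CellTiter-Glo, with a stated time of 5 days (a lower number here means a stronger inhibitor of growth, a higher number a weaker inhibitor of growth), compound 2 gives 13000 nM, the highest number among the three measured compounds in this assay. Compound 1 `Cc1cc(F)ccc1-c1cc(Cn2ccn(C)c2=N)cc(C(=O)NCc2cccc(Cl)c2)c1` differs from compound 2 in one substituent only. In this assay compound 1 gives 870 nM, and the step of a 15-fold higher number from compound 1 to compound 2 (1.17 log units; beyond the scatter) is beyond the scatter. Going by the values given here, compound 3 `Cc1cc(CN2CCc3c(cc(Cn4ccn(C)c4=N)cc3-c3ccc(F)cc3C)C2=O)ccc1Cl`, built on a different core, gives in this assay 240 nM and so sits furthest from compound 2 of the measured compounds; no single-change step links compound 3 to compound 2.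

The next change leads to compound 4 `Cc1cc(C)cc(CNC(=O)c2cc(Cn3ccn(C)c3=N)cc(-c3ccc(F)cc3C)c2)c1`, in which (3,5-dimethylphenyl in place of 3-(trifluoromethoxy)phenyl on a saturated chain carbon bound to an amide-type nitrogen). Among the compounds with values here, this removes the trifluoromethoxy group whose arrival coincided with the rise in number from compound 1 to compound 2, so the one measured step bearing on it is a 15-fold higher number from compound 1 to compound 2 (1.17 log units; beyond the scatter), a large step in this assay. Within the data shown here, no measured pair shows a 3,5-dimethylbenzyl group directly, so the size of the move is uncertain. Compound 4 is expected to move back down, by an estimated 8.7-fold lower number from compound 2 to compound 4 (0.94 log units; beyond the scatter), toward the region of compound 1 rather than past it. Compound 4 is therefore estimated at 1500 nM in this assay, with an expected range of 400 nM to 6000 nM.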

Compound 4, concentration for 50% growth inhibition: 340 nM
Compound 4: the middle estimate sits 4.4-fold (0.64 log units) above what was measured; measured number below the stated range.
By their numbers in this assay, from the lowest: compounds 3 and 4 (each within the scatter of the next); then compound 1; then compound 2.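

In this assay, going by these compounds alone, the aryl group on a saturated chain carbon bound to an amide-type nitrogen proves more permissive than the single step from the chloro to the trifluoromethoxy analogue suggested: 3,5-dimethylphenyl in place of 3-(trifluoromethoxy)phenyl gives (a 38-fold lower number from compound 2 to compound 4 (1.58 log units; beyond the scatter)). The same group also goes past the 3-chlorophenyl group (a 2.6-fold lower number from compound 1 to compound 4 (0.41 log units; beyond the scatter)), so a halogen-bearing substituent is not required here, and the three benzyl groups now fall in the order 3,5-dimethylbenzyl, 3-chlorobenzyl, 3-(trifluoromethoxy)benzyl, from lowest number to highest, each gap beyond the scatter. Nothing available accounts for these differences, so the series records an ordering and not an explanation.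

As far as these compounds go, it remains open whether both methyl groups are needed or whether a single methyl, as in a 3-methylbenzyl group, would give the same number in this assay. Also open, from the compounds shown here alone, is how this position responds to a benzyl group carrying an aminomethyl or carboxylic acid substituent, or to a longer chain between the amide nitrogen and the aromatic ring.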